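The compounds below may be only part of what the source reports. "The series", "measured", "known", "first", "only" and "open" are said of these compounds alone.

In an ADME assay on HEK293 cells (Homo sapiens) for cytotoxicity, read by MTT assay, with a stated time of 72 h (a lower number here means a stronger inhibitor, a higher number a weaker inhibitor), compound 1 `O=C(CN1CCN(C(=O)c2ccccc2)CC1)N1CCN(CCCc2c[nH]c3ccccc23)CC1` gives > 200000 nM, which is a limit of the assay and not a number. Compound 2 `O=C(CN1CCN(C(=O)c2cccc(Cl)c2)CC1)N1CCN(CCCc2c[nH]c3ccccc23)CC1` gives 99100 nM, and compound 3 `O=C(CN1CCN(C(=O)c2ccccc2F)CC1)N1CCN(CCCc2c[nH]c3ccccc23)CC1` gives 133000 nM. The next structure, compound 4 `O=C(CN1CCN(C(=O)c2ccccc2)CC1)N1CCN(CCCc2c[nH]c3ccc(F)cc23)CC1`, departs from compound 1 in one place: fluoro in place of hydrogen on an aromatic carbon. The 1H-indol-3-yl group becomes 5-fluoro-1H-indol-3-yl, with fluoro in place of hydrogen on an aromatic carbon.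

Two measured steps add a halogen to compound 1, though at a different aromatic group: an at least 2.0-fold lower number from compound 1 to compound 2 (0.30 log units; that floor lies within the scatter) with chloro, and an at least 1.5-fold lower number from compound 1 to compound 3 (0.17 log units; that floor lies within the scatter) with fluoro. Both sizes are floors only. The step between the two halogenated compounds is a 1.3-fold higher number from compound 2 to compound 3 (0.13 log units; within the scatter). Among the compounds with values here, no measured step places a halogen on the 1H-indol-3-yl group, so these steps are only an indirect guide.

Compound 3 at 133000 nM is the closest guide, as it also gains fluoro. A small move toward a lower number is therefore expected in this assay, not clearly beyond the scatter, and another limit reading remains possible. The expected change is an at least 1.4-fold lower number from compound 1 to compound 4 (0.15 log units; that floor lies within the scatter). The estimated value for compound 4 is 140000 nM, with an expected range of 80000 nM to 200000 nM.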

Compound 4, half-maximal inhibitory concentration: 148000 nM
Compound 4: middle estimate off by 1.1-fold (0.02 log units), on the low side, within the range that was stated.
By their numbers in this assay, from the lowest: compounds 2, 3 and 4 (each within the scatter of the next). At a limit, above all of these: compound 1.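

Placing fluoro on the 1H-indol-3-yl group, to give 5-fluoro-1H-indol-3-yl, provides the first reading for a halogen at this position, and in this assay the result is an at least 1.3-fold lower number from compound 1 to compound 4 (0.13 log units; that floor lies within the scatter). With compound 4 at 148000 nM, a measured number, halogen on either aromatic group now gives a reading inside the range of the assay in all three halogenated compounds, compounds 2, 3 and 4, and none of the three goes against this within the small set shown. The change can only be sized as a floor because the reference compound stands at a limit: the limit of > 200000 nM in this assay, at which 1 of the 4 values shown sits.

The compounds shown leave open whether chloro or methoxy at this position of the 5-fluoro-1H-indol-3-yl group's parent reads like fluoro, and whether an amine or a carboxylic acid there departs further from compound 1 in this assay. They also leave open how a compound carrying a halogen on both aromatic groups reads, and whether any single substitution on the core of compound 1 gives a step clearly beyond the scatter.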